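The source may hold more compounds than are shown below. What is called first, only, known or untested is meant among the compounds shown, and "the series" means these compounds.

Going by the values given here, in an assay on CHO-K1 cells for antagonist activity at transient receptor potential cation channel subfamily V member 1 (Homo sapiens), read by FLIPR and calcium flux, with a stated time of 6 min (a higher number here means a weaker inhibitor, a lower number a stronger inhibitor), compound 1 `CC(C)(C)c1cc(CNC(=O)Nc2cccc3[nH]ncc23)n(-c2cccc(Cl)c2)n1` gives 0.6 nM, the second highest of the three numbers measured so far. Its nearest neighbour is compound 2 `Cn1ncc2c(NC(=O)NCc3cc(C(C)(C)C)nn3-c3cccc(Cl)c3)cccc21`, which gives 0.4 nM; the step of a 1.5-fold lower number from compound 1 to compound 2 (0.18 log units; within the scatter) lies within the scatter. Furthest away is compound 3 `CC(=O)n1ncc2c(NC(=O)NCc3cc(C(C)(C)C)nn3-c3cccc(Cl)c3)cccc21`, which gives 29.5 nM; the step of a 49-fold higher number from compound 1 to compound 3 (1.69 log units; beyond the scatter) is large, and so is a 74-fold higher number from compound 2 to compound 3 (1.87 log units; beyond the scatter). All three measured steps turn on what sits on the aromatic nitrogen of the shared core. Compound 4 `CC(C)(C)c1cc(CNC(=O)Nc2cccc3[nH]ncc23)n(-c2cccc(F)c2)n1` differs from compound 1 somewhere else: fluoro in place of chloro on an aromatic carbon. Among the compounds with values here, none of the measured steps touches that ring, so none bears directly on this change, and the only guidance is that the rest of the molecule stays the same while one halogen replaces another in the same place. Compound 4 is therefore expected to stay within the scatter of compound 1, with the step of a 1.7-fold higher number from compound 1 to compound 4 (0.22 log units; within the scatter) estimated as small and of no settled direction. For compound 4 the estimate in this assay is 1 nM, expected to fall between 0.3 nM and 3 nM.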

Compound 4, inhibition constant: 1.3 nM
The estimate for compound 4 lay 1.3-fold (0.11 log units) below the measured number; the range from low to high includes it.
By their numbers in this assay, from the lowest: compounds 2 and 1 (each within the scatter of the next); then compound 4; then compound 3.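

In this assay, going by these compounds alone, the swap of 3-chlorophenyl for 3-fluorophenyl gives a 2.2-fold higher number from compound 1 to compound 4 (0.34 log units; beyond the scatter), so this ring position, which no earlier step touched, responds to the identity of the halogen even though only one heavy atom changes. The chloro group gives the lower number of the two, but the step is only modest, whereas the acetyl change on the aromatic nitrogen gives a 49-fold higher number from compound 1 to compound 3 (1.69 log units; beyond the scatter), which is large. No measurement here bears on why the two halogens differ.

The compounds shown leave open how a bromo, methyl or trifluoromethyl group would read in the same place, and how the unsubstituted phenyl would compare. They also leave open whether the same halogen swap gives a similar step when a methyl group sits on the aromatic nitrogen, as in compound 2.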